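Methoxy to methylsulfanyl on the aryl of the shared core

The source may report more compounds than this note shows. Statements on the series, on what has been measured and on what is new or still open speak of the compounds shown alone.

Going by the values given here, compound 2 `COc1ccc(C2=C(c3ccc(SC)cc3)CC3CCCN3C2=O)cc1` gives the highest of the two numbers recorded so far in a functional assay on SW-620 cells (Homo sapiens) for cytotoxicity (on this read-out higher numbers stand for weaker inhibition of growth and lower numbers for stronger inhibition of growth), at 3000 nM; its nearest neighbour, compound 1 `CSc1ccc(C2=C(c3ccc(C)c(C)c3)C(=O)N3CCCC3C2)cc1`, gives 700 nM, and the change between them, a 4.3-fold higher number from compound 1 to compound 2 (0.63 log units; beyond the scatter), is the only measured step on this ring. Compound 3 `CSc1ccc(C2=C(c3ccc(SC)cc3)C(=O)N3CCCC3C2)cc1` has not yet been measured in this assay. methylsulfanyl in place of methoxy on an aromatic carbon The new group sits on an aromatic carbon of a six-membered aromatic ring of carbon only, para to a large group. Among the compounds with values here, no measured pair matches this exact change; the one step available shows only that substitution on this ring moves the read-out by a modest amount. On that basis a modest step back toward the number of compound 1 is expected, giving a 2.3-fold lower number from compound 2 to compound 3 (0.36 log units; beyond the scatter) for compound 3. Compound 3 is therefore estimated at 1300 nM, with a range of 500 nM to 3500 nM.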

Compound 3, concentration for 50% growth inhibition: 7000 nM
Compound 3: the middle estimate sits 5.4-fold (0.73 log units) below what was measured; measured number above the stated range.
By their numbers in this assay, from the lowest: compound 1; then compound 2; then compound 3.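

In this assay, methylsulfanyl in place of methoxy on this aromatic carbon gives a 2.3-fold higher number from compound 2 to compound 3 (0.37 log units; beyond the scatter), so the read-out separates these two groups, and the change moves away from compound 1, not toward it. Replacing 3,4-dimethylphenyl at the same place with 4-(methylsulfanyl)phenyl gives a 10-fold higher number from compound 1 to compound 3 (1.00 log units; beyond the scatter), the largest step in the set, and both 4-substituted aryl groups with a heteroatom read higher than 3,4-dimethylphenyl. No measured evidence bears on the reason for this result.

The compounds shown leave open how a 4-methylphenyl or a 4-aminophenyl would read at this place, and so whether both methyl groups of compound 1 are needed for its lower number. As far as these compounds go, it also remains open whether the order of methoxy and methylsulfanyl holds with a different aryl partner on the shared core.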